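A Second Chloro on the Core of Compound 1

The source may report more compounds than this note shows. Statements on the series, on what has been measured and on what is new or still open speak of the compounds shown alone.

compound 1 `ClCc1ccc(Cn2cnc3c(Cl)ncnc32)cc1`: 1020 nM
compound 2 `ClCc1ccccc1Cn1cnc2c(Cl)ncnc21`: 17800 nM
compound 3 `ClCc1ccccc1Cn1cnc2ncnc(Cl)c21`: 3980 nM

Of the compounds shown here, three have been measured in a functional assay on 786-0 cells (Homo sapiens) for cytotoxicity, read by sulforhodamine B assay, with a stated time of 48 h; a higher number here means a weaker inhibitor of growth, a lower number a stronger inhibitor of growth. Among them compound 1 stands lowest. Its nearest neighbour is compound 3, whose number lies higher by a margin beyond the usual scatter of this assay, and the furthest is compound 2, whose number is higher still, also well beyond the scatter. Compound 1 is therefore the strongest inhibitor of growth of the three on the numbers shown.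

The next compound, compound 4 `ClCc1ccc(Cn2cnc3c(Cl)nc(Cl)nc32)cc1`, keeps the whole of compound 1 and differs from it in one place only: chloro in place of hydrogen on an aromatic carbon. Going by the values given here, no pair of measured compounds isolates this particular change, so its effect cannot be read from an existing step; the measured differences among compounds 1, 2 and 3 concern other parts of the molecule. With one more chlorine added to a core that already carries a chloro group, the step is expected to be small. The expected step from compound 1 to compound 4 in this assay is a 1.3-fold lower number from compound 1 to compound 4 (0.11 log units; within the scatter), a change that may lie within the scatter, with a slight leaning toward a lower number. Compound 4 is accordingly estimated at 800 nM, with a range from 250 nM to 2500 nM.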

Compound 4, concentration for 50% growth inhibition: 14100 nM
Compound 4: middle estimate off by 18-fold (1.25 log units), on the low side, outside the stated range (above it).
By their numbers in this assay, from the lowest: compound 1; then compound 3; then compounds 4 and 2 (each within the scatter of the next).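

In this assay, chloro in place of hydrogen on the aromatic carbon between two ring nitrogen atoms gives a 14-fold higher number from compound 1 to compound 4 (1.14 log units; beyond the scatter), a large step for the entry of a single heavy atom. Going by these compounds alone, this is the first pair of measured compounds to isolate this position, and it shows that the carbon is far from indifferent: with the rest of compound 1 unchanged, this one replacement is enough to make compound 4 a much weaker inhibitor of growth. Nothing available explains why the step is so large.

The compounds shown leave open whether an amine or a methyl group on this same carbon would give a number close to that of compound 1, close to that of compound 4, or elsewhere, so it cannot yet be said whether the loss belongs to chloro or to any replacement of the hydrogen. Also open, as far as these compounds go, is whether the same chloro, placed on the corresponding carbon of compound 2 or compound 3, would bring a step of similar size.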